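Replacing thiophen-3-yl with 1-methyl-1H-pyrazol-5-yl on the amide

The compounds below may be only part of what the source reports. "The series", "measured", "known", "first", "only" and "open" are said of these compounds alone.

In a functional assay on A549 cells (Homo sapiens) for inhibition, read by colorimetric assay and sulforhodamine B assay, with a stated time of 48 h (on this read-out lower numbers stand for stronger inhibition of growth and higher numbers for weaker inhibition of growth), compound 1 `CCCCCCCCCCCC[C@@H](O)[C@H]1CC[C@H]([C@H](O)CCCCCCCCCCNC(=O)c2cccs2)O1` gives 3720 nM and compound 2 `CCCCCCCCCCCC[C@@H](O)[C@H]1CC[C@H]([C@H](O)CCCCCCCCCCNC(=O)c2ccco2)O1` gives 100000 nM. Compound 3 `CCCCCCCCCCCC[C@@H](O)[C@H]1CC[C@H]([C@H](O)CCCCCCCCCCNC(=O)c2ccsc2)O1` gives 100000 nM, level with compound 2 and well above compound 1. Compound 4 `CCCCCCCCCCCC[C@@H](O)[C@H]1CC[C@H]([C@H](O)CCCCCCCCCCNC(=O)c2ccnn2C)O1` carries 1-methyl-1H-pyrazol-5-yl in place of thiophen-3-yl on a carbonyl carbon. Among the compounds with values here, three measured steps bear on this change. Two were large, a 27-fold higher number from compound 1 to compound 2 (1.43 log units; beyond the scatter) and a 27-fold higher number from compound 1 to compound 3 (1.43 log units; beyond the scatter), while the third showed no change at the digits printed from compound 2 to compound 3 (within the scatter). Among these three compounds, only the thiophen-2-yl of compound 1 stands apart, so no step beyond the scatter is expected here. The estimated step is a 1.4-fold lower number from compound 3 to compound 4 (0.15 log units; within the scatter). Compound 4 is expected at 70000 nM, within an estimated range of 10000 nM to 120000 nM.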

Compound 4, concentration for 50% growth inhibition: 12900 nM
The estimate for compound 4 lay 5.4-fold (0.73 log units) above the measured number, within the range that was stated.
By their numbers in this assay, from the lowest: compound 1; then compound 4; then compounds 2 and 3 (each within the scatter of the next).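

In this assay the ring on this carbonyl carbon need not be thiophen-2-yl to give a measurable gain over the weakest compounds, as a 7.8-fold lower number from compound 3 to compound 4 (0.89 log units; beyond the scatter) and a 7.8-fold lower number from compound 2 to compound 4 (0.89 log units; beyond the scatter) both show, even though a 3.5-fold higher number from compound 1 to compound 4 (0.54 log units; beyond the scatter) leaves 1-methyl-1H-pyrazol-5-yl behind thiophen-2-yl. Ring sulfur is therefore neither required, given compound 4, nor sufficient, given compound 3. Nothing available explains this order among the rings.

Going by these compounds, whether the methyl group on the pyrazole contributes remains open, and so does how a phenyl or pyridin-2-yl ring would compare in this place.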